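From 3-bromophenyl to 4-methylphenyl on the shared core

The source may hold more compounds than are shown below. What is called first, only, known or untested is meant among the compounds shown, and "the series" means these compounds.

In a functional assay on U-251 cells (Homo sapiens) for antiproliferative activity, read by MTT assay, with a stated time of 48 h (a lower number here means a stronger inhibitor, a higher number a weaker inhibitor), compound 1 `COc1cc(-c2cccc3nc(-c4cccc(F)c4)oc23)cc(OC)c1OC` gives 2900 nM. Among the compounds with values here, compound 3 `COc1cc(-c2cccc3nc(-c4cccc(Br)c4)oc23)cc(OC)c1OC` gives 6800 nM, the higher of the two true numbers so far. The gap between them is modest: a 2.3-fold higher number from compound 1 to compound 3 (0.37 log units; beyond the scatter). Compound 2 `COc1cc(-c2cccc3nc(-c4ccc(F)cc4)oc23)cc(OC)c1OC` reads > 25000 nM, which is a limit of the assay and not a number.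

Next comes compound 4 `COc1cc(-c2cccc3nc(-c4ccc(C)cc4)oc23)cc(OC)c1OC`, with 4-methylphenyl in place of 3-bromophenyl on an aromatic carbon. Within the data shown here, the closest precedent is an at least 8.6-fold higher number from compound 1 to compound 2 (0.93 log units; beyond the scatter), where 4-fluorophenyl replaces 3-fluorophenyl. The same contrast appears as an at least 3.6-fold lower number from compound 2 to compound 3 (0.56 log units; beyond the scatter), where 3-bromophenyl replaces 4-fluorophenyl. As far as these compounds go, both steps rest on the limit, so their true sizes remain open. Among the measured compounds shown here, no methyl-bearing compound has been measured, so that group has no direct precedent, and only the single fluoro pair supports the contrast between the named groups. A higher number is therefore expected in this assay, beyond the scatter but possibly smaller than the fluoro step. The expected change is a 2.2-fold higher number from compound 3 to compound 4 (0.34 log units; beyond the scatter). A reading at the assay limit would not be surprising. For compound 4 the estimated value is 15000 nM, with an expected range of 6000 nM to 25000 nM.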

Compound 4, half-maximal inhibitory concentration: 3200 nM
For compound 4 the middle estimate is 4.7-fold (0.67 log units) above the measured one, outside the stated range (below it).
By their numbers in this assay, from the lowest: compounds 1 and 4 (each within the scatter of the next); then compound 3. At a limit, above all of these: compound 2.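

In this assay, a group at the 4-position of the phenyl ring on this aromatic carbon does not by itself bring a weak reading, since a 2.1-fold lower number from compound 3 to compound 4 (0.33 log units; beyond the scatter) runs against the contrast suggested by the fluoro pair. The 4-methylphenyl of compound 4 and the 3-fluorophenyl of compound 1 are not separated in this read-out, with a 1.1-fold higher number from compound 1 to compound 4 (0.04 log units; within the scatter), so the pattern of 3-substituted over 4-substituted phenyl does not hold across the series, and compound 4 is the compound that goes against it. Compound 2 gives a limit and not a number, so the step of an at least 7.8-fold lower number from compound 2 to compound 4 (0.89 log units; beyond the scatter) has no fixed size and shows only that 4-methylphenyl and 4-fluorophenyl differ at this place: the limit of > 25000 nM in this assay, at which 1 of the 4 values shown sits.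

The compounds shown leave open whether the change from compound 2 to compound 4 follows the methyl group alone or would also appear with 4-chlorophenyl, 4-methoxyphenyl or 4-aminophenyl. They also leave open how 3-methylphenyl and 4-bromophenyl would read on the shared core, which would show whether moving a single group between these two ring positions matters beyond fluoro.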